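Ortho-methoxy on the aryl of a sulfamide piperidine series

A few compounds are considered here, and "the series" means these few. Any claim that something is new, unique, unknown or untested is made for them only; others in the source may bear on it.

Compound 1 `NS(=O)(=O)NCC1CCN(c2cc(-c3ccccc3)ncn2)CC1` is the parent of the set. In a functional assay on M21 cells (Homo sapiens) for antiproliferative activity, read by sulforhodamine B assay, with a stated time of 48 h (on this read-out higher numbers stand for weaker inhibition of growth and lower numbers for stronger inhibition of growth), compound 1 gives > 100000 nM, which is a limit of the assay and not a number. Compound 2 `COc1ccc(-c2cc(N3CCC(CNS(N)(=O)=O)CC3)ncn2)cc1` carries a methoxy on the aromatic carbon; in this assay compound 2 gives > 100000 nM, again a limit. Compound 3 `NS(=O)(=O)NCC1CCN(c2cc(-c3ccc(C(F)(F)F)cc3)ncn2)CC1` carries a trifluoromethyl instead; in this assay compound 3 gives 43100 nM. The step from compound 1 to compound 2 is a step that the two limits leave unreadable from compound 1 to compound 2, because of the limit of > 100000 nM in this assay, at which 2 of the 3 values shown sit; the step from compound 1 to compound 3 is an at least 2.3-fold lower number from compound 1 to compound 3 (0.36 log units; beyond the scatter), and that from compound 2 to compound 3 is an at least 2.3-fold lower number from compound 2 to compound 3 (0.36 log units; beyond the scatter).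

Compound 4 `COc1ccccc1-c1cc(N2CCC(CNS(N)(=O)=O)CC2)ncn1` differs from compound 1 by methoxy in place of hydrogen on an aromatic carbon. Within the data shown here, the only measured change of the same kind, a methoxy in compound 2, left the number at the limit, so no step beyond the scatter is expected in this assay for compound 4, and an estimate of a step that the limit leaves unreadable from compound 1 to compound 4 is the plain reading. Compound 4 is therefore expected to give about 150000 nM, with a range of 60000 nM to 400000 nM, most likely again reported as a limit.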

Compound 4, concentration for 50% growth inhibition: > 100000 nM
Compound 4 gave a limit, no number; the forecaster's own chance of this, stated with the estimate: 80%; the middle value does not contradict the limit.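

In this assay compound 4 gives > 100000 nM, a limit of the assay and not a number. Its steps from compound 1 and from compound 2 therefore cannot be read, because all three compounds sit at the same limit: the limit of > 100000 nM in this assay, at which 3 of the 4 values shown sit. The compounds shown leave open whether 2-methoxyphenyl or 4-methoxyphenyl in place of phenyl changes growth inhibition at all.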